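A few compounds are considered here, and "the series" means these few. Any claim that something is new, unique, unknown or untested is made for them only; others in the source may bear on it.

Compound 3 `CCOC(=O)c1c(C)[nH]c(=O)c(C#N)c1-c1ccc(C#N)cc1` gives 9320 nM in a functional assay on MCF7 cells (Homo sapiens) for inhibition, read by MTT assay, with a stated time of 24 h (on this read-out higher numbers stand for weaker inhibition and lower numbers for stronger inhibition), the second highest of the three numbers shown. Compound 2 `CCOC(=O)c1c(C)[nH]c(=O)c(C#N)c1-c1ccc(C)cc1` gives 8000 nM, and a 1.2-fold higher number from compound 2 to compound 3 (0.07 log units; within the scatter). Compound 1 `CCOC(=O)c1c(C)[nH]c(=O)c(C#N)c1-c1ccccc1` gives 22000 nM, and a 2.4-fold lower number from compound 1 to compound 3 (0.37 log units; beyond the scatter). Compound 4 `CCOC(=O)c1c(C)[nH]c(=O)c(C#N)c1-c1ccc(Br)cc1` differs from compound 3 by bromo in place of cyano on an aromatic carbon. Among the measured compounds shown here, no measured step puts a bromo group into that place; the two steps that put any group there, a 2.8-fold lower number from compound 1 to compound 2 (0.44 log units; beyond the scatter) and a 2.4-fold lower number from compound 1 to compound 3 (0.37 log units; beyond the scatter), were both modest and alike, and the two unlike groups gave numbers within the scatter of each other. On that basis the step to compound 4 is expected to be a 1.1-fold lower number from compound 3 to compound 4 (0.04 log units; within the scatter), with no change beyond the scatter. Compound 4 is therefore estimated at 8500 nM, with a range from 3000 nM to 25000 nM.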

Compound 4, half-maximal inhibitory concentration: 31800 nM
The estimate for compound 4 lay 3.7-fold (0.57 log units) below the measured number, outside the stated range (above it).
By their numbers in this assay, from the lowest: compounds 2 and 3 (each within the scatter of the next); then compounds 1 and 4 (each within the scatter of the next).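

In this assay, the groups at this place are not interchangeable: putting bromo there gives a 3.4-fold higher number from compound 3 to compound 4 (0.53 log units; beyond the scatter) and a 4.0-fold higher number from compound 2 to compound 4 (0.60 log units; beyond the scatter), although cyano and methyl had given numbers within the scatter of each other. Set against hydrogen, bromo gives a 1.4-fold higher number from compound 1 to compound 4 (0.16 log units; within the scatter), which lies within the scatter, so having a group at this place does not by itself lower the number. Nothing available bears on why bromo parts from cyano and methyl here. From the compounds shown here alone, whether an amine, a carboxylic acid or a methoxy group at this place would track methyl and cyano or track bromo stays open. So does whether these steps would hold with the group elsewhere on the aromatic ring.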